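Iodo in place of thiophen-3-yl: compound 3 in prospect

This account rests on a few compounds, and the source may have more. Where it says the series, first, only, none or still open, it means among the compounds named here.

In a functional assay on HepG2 cells (Homo sapiens) for antiproliferative activity, read by XTT assay, with a stated time of 72 h (a higher number here means a weaker inhibitor, a lower number a stronger inhibitor), compound 1 `CNc1ncnc2c1c(-c1ccsc1)cn2[C@@H]1O[C@H](CO)[C@@H](O)[C@H]1O` reads > 20000 nM, which is a limit of the assay and not a number. Going by the values given here, compound 2 `Cc1ncnc2c1c(-c1ccsc1)cn2[C@@H]1O[C@H](CO)[C@@H](O)[C@H]1O` gives 4720 nM, the only true number so far. Among the compounds with values here, the one measured step is an at least 4.2-fold lower number from compound 1 to compound 2 (0.62 log units; beyond the scatter), with methyl in place of methylamino on an aromatic carbon.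

Compound 3 `Cc1ncnc2c1c(I)cn2[C@@H]1O[C@H](CO)[C@@H](O)[C@H]1O` keeps the methyl of compound 2 and changes another place on the shared core: iodo in place of thiophen-3-yl on an aromatic carbon. In short, this is iodo in place of thiophen-3-yl on an aromatic carbon. The measured step lies elsewhere on the core, so it bears on this change only indirectly, showing that one exchanged group can move the reading in this assay. Within the data shown here, no step at the thiophen-3-yl carbon has been measured, so no direction is favoured, and the central expectation in this assay is no step beyond the scatter, with wide uncertainty. The expected change is a 1.6-fold lower number from compound 2 to compound 3 (0.20 log units; within the scatter). For compound 3 the estimated value is 3000 nM, with an expected range from 400 nM to 20000 nM.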

Compound 3, half-maximal inhibitory concentration: 3460 nM
Compound 3: the middle estimate sits 1.2-fold (0.06 log units) below what was measured; the measured number falls inside the stated range.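

In this assay, iodo in place of thiophen-3-yl on the aromatic carbon two ring bonds from the ring nitrogen gives a 1.4-fold lower number from compound 2 to compound 3 (0.13 log units; within the scatter). Going by these compounds alone, this is the first reading at this position, and with the methyl held constant, a single iodine atom and a five-membered aromatic ring of 5 heavy atoms cannot be told apart in this assay. The only step beyond the scatter therefore remains the one at the other place, methyl in place of methylamino, and the limit belonging to compound 1 does not touch the present pair: the limit of > 20000 nM in this assay, at which 1 of the 3 values shown sits.

Going by these compounds, two groups at this carbon say little about its wider scope, so it remains open how an amine, a carboxylic acid or a longer alkyl chain would read there, and whether plain hydrogen would match iodo and thiophen-3-yl. Also open, on these data alone, is whether iodo and thiophen-3-yl would still read alike with methylamino in place of methyl, as this comparison rests on a single pair that carries the methyl.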